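Swapping methoxy for (trifluoromethyl)sulfanyl on an aromatic ring

The compounds below may be only part of what the source reports. "The series", "measured", "known", "first", "only" and "open" are said of these compounds alone.

Three amides sharing one core have been tested for their power to slow the growth of liver cancer cells. Compound 1 `COc1cccc(NC(=O)C(Cl)Cl)c1` carries a methoxy group on its aromatic ring; compound 2 `O=C(Nc1cccc(SC(F)(F)F)c1)C(Cl)Cl` carries (trifluoromethyl)sulfanyl in its place; compound 3 `COc1ccc(NC(=O)C(Cl)Cl)cc1` has the same atoms as compound 1, joined differently, and how these two cores differ is not broken down here. In a functional assay on Bel-7402 cells (Homo sapiens) for antiproliferative activity, read by MTT assay, with a stated time of 72 h (a higher number here means a weaker inhibitor, a lower number a stronger inhibitor), compound 1 gives 54800 nM, compound 2 gives 6540 nM, and compound 3 gives 192000 nM, the highest number of the three. The change (trifluoromethyl)sulfanyl in place of methoxy on an aromatic carbon produced an 8.4-fold lower number from compound 1 to compound 2 (0.92 log units; beyond the scatter). Compound 4 `O=C(Nc1ccc(SC(F)(F)F)cc1)C(Cl)Cl` is not yet measured; it arises from compound 3 through ((trifluoromethyl)sulfanyl in place of methoxy on an aromatic carbon), the same kind of change, though here the new group sits para to a group of 6 heavy atoms rather than meta to it. Resting on that single measured example, an 8.4-fold lower number from compound 1 to compound 2 (0.92 log units; beyond the scatter), a step of about the same size is expected, an 8.3-fold lower number from compound 3 to compound 4 (0.92 log units; beyond the scatter). On that basis compound 4 is expected to land near 23000 nM, most likely between 8000 nM and 70000 nM.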

Compound 4, half-maximal inhibitory concentration: 3610 nM
Beside the measured number, compound 4's estimate is 6.4-fold (0.80 log units) above it; measured number below the stated range.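

On the core of compound 3, swapping methoxy for (trifluoromethyl)sulfanyl in this assay gives a 53-fold lower number from compound 3 to compound 4 (1.73 log units; beyond the scatter), so the number falls on this core as it did on the first one. The direction of the step repeats across the two cores, but its size does not carry over unchanged: the same change on two cores in this assay, an 8.4-fold lower number (0.92 log units; beyond the scatter) from compound 1 to compound 2 and a 53-fold lower number (1.73 log units; beyond the scatter) from compound 3 to compound 4, 6.3-fold (0.80 log units) apart, beyond the scatter of two such steps. This means that a step measured on one core in this series gives a fair guide to direction but only a rough guide to size; with just two pairs, it does not show why the two steps differ, nor how large the step would be on any further core.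

The compounds shown hold only methoxy or (trifluoromethyl)sulfanyl on the aromatic ring, so it remains open how an amine, a carboxylic acid or a longer chain at the same place would compare. As far as these compounds go, it also remains open whether the same swap would lower the number in other cell lines.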